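Removing a chloro group from a thiophene-linked benzamidine

This account rests on a few compounds, and the source may have more. Where it says the series, first, only, none or still open, it means among the compounds named here.

Measured so far:
compound 1 `N=C(N)c1ccc(-c2ccc(-c3ccc(Cl)cc3)s2)cc1F` — 394 nM
compound 2 `COc1cc(OC)cc(-c2ccc(-c3ccc(C(=N)N)c(F)c3)s2)c1` — 1300 nM

In a functional assay on PC-3 cells (Homo sapiens) for inhibition, read by sulforhodamine B assay, with a stated time of 48 h (on this read-out higher numbers stand for weaker inhibition of growth and lower numbers for stronger inhibition of growth), compound 1 gives 394 nM, the lower of the two numbers; compound 2 sits at 1300 nM, a gap beyond the usual scatter. Compound 3 `N=C(N)c1ccc(-c2ccc(-c3ccccc3)s2)cc1F` is not yet measured. It differs from compound 1 in one place, (hydrogen in place of chloro on an aromatic carbon), on an aromatic carbon of a six-membered aromatic ring of carbon only, para to a large group. Going by the values given here, no such step has yet been measured here, so the change is expected to give a modest rise in number, roughly a 2.0-fold higher number from compound 1 to compound 3 (0.31 log units; beyond the scatter), toward weaker growth inhibition. Compound 3 is therefore estimated at 800 nM, within 300 nM to 2500 nM.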

Compound 3, concentration for 50% growth inhibition: 4180 nM
Beside the measured number, compound 3's estimate is 5.2-fold (0.72 log units) below it, outside the stated range (above it).
By their numbers in this assay, from the lowest: compound 1; then compound 2; then compound 3.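

In this assay, going by these compounds alone, the change from 4-chlorophenyl to phenyl gives an 11-fold higher number from compound 1 to compound 3 (1.03 log units; beyond the scatter) and is the first single-place step seen. Losing one heavy atom at this position, para to a large group, thus costs much of the growth inhibition seen with compound 1, so the chloro group matters here. No evidence at hand explains this loss.

From the compounds shown here alone, it remains open whether a bromo, methyl, methoxy or amine group at the same position would match chloro or fall closer to hydrogen.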